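The source may hold more compounds than are shown below. What is called first, only, known or untested is meant among the compounds shown, and "the series" means these compounds.

Measured so far in a functional assay on Jurkat cells (Homo sapiens) for inhibition, read by CCK-8 assay, with a stated time of 48 h; on this read-out higher numbers stand for weaker inhibition of growth and lower numbers for stronger inhibition of growth

- Compound 1 `Cc1ccccc1Nc1nc(Nc2ccc(N3CCN(C)CC3)cc2)ncc1Cl` gives 13700 nM
- Compound 2 `Cc1ccccc1Nc1nc(Nc2ccc(N3CCCN(C)CC3)cc2)ncc1Cl` gives 11300 nM
- Compound 3 `COc1cccc(CNc2nc(Nc3ccc(N4CCN(C)CC4)cn3)ncc2Cl)c1` gives 73400 nM

Compound 3 has the highest number of the three, which makes it the weakest growth inhibitor so far. Compound 4 `CC(C)c1ccccc1Nc1nc(Nc2ccc(N3CCN(C)CC3)cn2)ncc1Cl` differs from it in one group: 2-isopropylphenyl in place of 3-methoxybenzyl on a nitrogen on an aromatic ring. Put simply, 2-isopropylphenyl takes the place of 3-methoxybenzyl on a nitrogen on an aromatic ring.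

Among the measured compounds shown here, no measured step isolates this swap. The only one, a 1.2-fold lower number from compound 1 to compound 2 (0.08 log units; within the scatter), concerns a different part of the molecule and stays within the scatter, so it offers little guidance. The closest comparison is compound 1, which also has a substituted phenyl directly on that nitrogen and gives 13700 nM. Compound 2 shares that group and gives 11300 nM. Both also differ from compound 3 elsewhere, so this is only indirect evidence, but it points towards a lower number in this assay. The expected change is a 3.3-fold lower number from compound 3 to compound 4 (0.52 log units; beyond the scatter). For compound 4 the estimated value is 22000 nM, with an expected range from 8000 nM to 60000 nM.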

Compound 4, concentration for 50% growth inhibition: 5140 nM
The estimate for compound 4 lay 4.3-fold (0.63 log units) above the measured number; measured number below the stated range.
By their numbers in this assay, from the lowest: compound 4; then compounds 2 and 1 (each within the scatter of the next); then compound 3.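

In this assay the group on this nitrogen proves to matter a great deal: 2-isopropylphenyl in place of 3-methoxybenzyl gives a 14-fold lower number from compound 3 to compound 4 (1.15 log units; beyond the scatter) and counts as a large step. Among the compounds shown here, the only earlier step, a 1.2-fold lower number from compound 1 to compound 2 (0.08 log units; within the scatter), lay in a different part of the molecule and stayed within the scatter, so this is the first sign that a single change can shift growth inhibition well beyond it. Nothing measured here explains the size of this step.

The swap changes two things at once, the ring now sitting directly on the nitrogen and methoxy giving way to isopropyl, and the compounds shown do not separate them. Groups such as plain benzyl or 2-methoxyphenyl at this nitrogen, on the core of compound 4, would be needed to tell which matters.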